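This account rests on a few compounds, and the source may have more. Where it says the series, first, only, none or still open, it means among the compounds named here.

Compound 1 `COc1ccc(OC)c(COc2cc(NC(=O)c3ccc(I)cc3)ccc2NS(C)(=O)=O)c1` and compound 2 `COc1ccc(OC)c(COc2cc(NC(=O)c3ccc4ccccc4c3)ccc2NS(C)(=O)=O)c1` share one core and were tested in a functional assay on SK-BR-3 cells (Homo sapiens) for antiproliferative activity, read by MTT assay, with a stated time of 48 h; a lower number here means a stronger inhibitor, a higher number a weaker inhibitor. Compound 1 gives 11.8 nM, and compound 2 gives 13.3 nM. The change between them, (naphthalen-2-yl in place of 4-iodophenyl on a carbonyl carbon), made a step of a 1.1-fold higher number from compound 1 to compound 2 (0.05 log units; within the scatter). Compound 3 `Cc1ccc(C)c(COc2cc(NC(=O)c3ccc(I)cc3)ccc2N(C)S(=O)(=O)C(F)(F)F)c1` has a different core; the difference between the two cores is not broken down here. In this assay compound 3 gives 13500 nM. Compound 4 `Cc1ccc(C)c(COc2cc(NC(=O)c3ccc4ccccc4c3)ccc2N(C)S(=O)(=O)C(F)(F)F)c1` has not yet been measured; it carries the same change, (naphthalen-2-yl in place of 4-iodophenyl on a carbonyl carbon), at the same place. Because a 1.1-fold higher number from compound 1 to compound 2 (0.05 log units; within the scatter) stayed within the scatter, the expected step of a 1.1-fold higher number from compound 3 to compound 4 (0.05 log units; within the scatter) is also small. Compound 4 is therefore estimated at 15000 nM, expected to lie between 5000 nM and 45000 nM.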

Compound 4, half-maximal inhibitory concentration: 41400 nM
Estimate against measurement, compound 4: 2.8-fold (0.44 log units) below; low and high end bracket the measured number.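

In this assay, putting naphthalen-2-yl in place of 4-iodophenyl on the carbonyl carbon gave a 3.1-fold higher number from compound 3 to compound 4 (0.49 log units; beyond the scatter), so a change that made little difference on the core of compound 1 did not carry over unchanged to the core of compound 3. Setting the two steps side by side shows that the effect of this change depends on the core: the same change on two cores in this assay, a 1.1-fold higher number (0.05 log units; within the scatter) from compound 1 to compound 2 and a 3.1-fold higher number (0.49 log units; beyond the scatter) from compound 3 to compound 4, 2.7-fold (0.43 log units) apart, beyond the scatter of two such steps. For the compounds shown here, this rests on only one pair of compounds per core, and it does not show which feature of the cores lies behind the gap.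

Going by these compounds, it remains open which of the differences between the two cores matters. Also open, on these data alone, is how a carboxylic acid or a cyclohexyl group on the same carbonyl carbon would behave on each core.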